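The source may hold more compounds than are shown below. What is called first, only, known or untested is meant among the compounds shown, and "the series" means these compounds.

In a functional assay on HT-29 cells (Homo sapiens) for inhibition, read by luminescence and CellTiter-Glo, with a stated time of 24 h (a higher number here means that more compound is needed for the effect, a lower number that less compound is needed), three compounds sharing one core are compared, and they differ only in the group on an aromatic nitrogen. Compound 1 (`CN1C(=S)[C@@H](NC(=O)c2nc(Cc3ccccc3)n(CCCF)n2)COc2ccccc21`) carries 3-fluoropropyl and reaches 4760 nM as its half-maximal effective concentration. Compound 2 (`CN1C(=S)[C@@H](NC(=O)c2nc(Cc3ccccc3)n(CCCC#N)n2)COc2ccccc21`) carries 3-cyanopropyl and reaches 2400 nM on the same read-out. Compound 3 (`CN1C(=S)[C@@H](NC(=O)c2nc(Cc3ccccc3)n(C3CCNCC3)n2)COc2ccccc21`) carries piperidin-4-yl and stands lowest of the three at 1000 nM on that read-out.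

Compound 4 (`CN1C(=S)[C@@H](NC(=O)c2nc(Cc3ccccc3)n(Cc3ccccc3)n2)COc2ccccc21`) keeps the core of compound 3 but has benzyl in place of piperidin-4-yl on an aromatic nitrogen. Within the data shown here, two measured steps bear on this change. They are the ones that involve piperidin-4-yl at this same place. Both are modest and beyond the scatter (a 4.8-fold lower number from compound 1 to compound 3 (0.68 log units; beyond the scatter); a 2.4-fold lower number from compound 2 to compound 3 (0.38 log units; beyond the scatter)). The step between the two chains (a 2.0-fold lower number from compound 1 to compound 2 (0.30 log units; within the scatter)) lies within the scatter and says little here.

No benzyl on this nitrogen has been measured, so the expectation is only a loose one. Going by those two steps, in this assay a modest move to a higher number is expected, and the estimated change is a 2.5-fold higher number from compound 3 to compound 4 (0.40 log units; beyond the scatter) in size. For compound 4 the estimated value is 2500 nM with an expected range from 900 nM to 7000 nM around it.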

Compound 4, half-maximal effective concentration: 414 nM
Estimate against measurement, compound 4: 6.0-fold (0.78 log units) above; measured number below the stated range.
By their numbers in this assay, from the lowest: compound 4; then compound 3; then compounds 2 and 1 (each within the scatter of the next).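

In this assay, a group with one six-membered aromatic ring of carbon only can take the place of piperidin-4-yl on this aromatic nitrogen and the number still falls (a 2.4-fold lower number from compound 3 to compound 4 (0.38 log units; beyond the scatter)), so the hydrogen-bond donor and acceptor that leave with piperidin-4-yl are not needed for a low number among these four compounds. The benzyl group also separates clearly from both chains, with a modest step from the nitrile chain (a 5.8-fold lower number from compound 2 to compound 4 (0.76 log units; beyond the scatter)) and a large one from the fluorinated chain (an 11-fold lower number from compound 1 to compound 4 (1.06 log units; beyond the scatter)), which makes compound 4 the lowest of the set and shows that this position can shift the number widely. Nothing available explains why benzyl gives the lowest number here.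

The compounds shown leave open whether the aromatic character of the ring matters, which a cyclohexylmethyl group on the same nitrogen would help to test against benzyl. They also leave open how the number responds to a chlorine or a methoxy group on the benzyl ring, or to a longer link such as 2-phenylethyl.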